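Compound 3 after the limit of compound 2

The source may hold more compounds than are shown below. What is called first, only, known or untested is meant among the compounds shown, and "the series" means these compounds.

Measured in an ADME assay on PBMC cells (Homo sapiens) for cytotoxicity, with a stated time of 5 days; a higher number here means a weaker inhibitor, a lower number a stronger inhibitor:
Compound 1 `[N-]=[N+]=N[C@H]1C[C@H](n2cnc3c(NC4CC4)nc(Cl)nc32)O[C@@H]1CO`: 35300 nM
Compound 2 `COc1nc(Cl)nc2c1ncn2[C@H]1C[C@H](N=[N+]=[N-])[C@@H](CO)O1`: > 100000 nM (a limit of the assay, not a number)

Going by these compounds, compound 2 stands at the limit of > 100000 nM in this assay, at which 1 of the 2 values shown sits, so its true position is unknown and only a limit can be stated. The next structure, compound 3 `[N-]=[N+]=N[C@H]1C[C@H](n2cnc3c(N)nc(Cl)nc32)O[C@@H]1CO`, has not yet been measured. It carries amino in place of methoxy on an aromatic carbon.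

Going by the values given here, one measured step bears on this change. It concerns the same aromatic carbon, where methoxy replaces cyclopropylamino, and it gives an at least 2.8-fold higher number from compound 1 to compound 2 (0.45 log units; beyond the scatter). That step is beyond the scatter, though its full size is hidden by the limit. Compound 3 reverses the exchange in part, since amino replaces methoxy, so it is expected to fall back towards compound 1, which gives 35300 nM. Amino is not cyclopropylamino, however, so this single step is only a loose guide.

The expected change is a modest move to a lower number in this assay, given as an at least 1.6-fold lower number from compound 2 to compound 3 (0.22 log units; that floor lies within the scatter). For compound 3 the estimated value is 60000 nM, with an expected range from 20000 nM to 100000 nM.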

Compound 3, half-maximal inhibitory concentration: 35800 nM
Estimate against measurement, compound 3: 1.7-fold (0.22 log units) above; the measured number falls inside the stated range.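

In this assay, amino in place of methoxy on this aromatic carbon gives an at least 2.7-fold lower number from compound 2 to compound 3 (0.44 log units; beyond the scatter) and thus shows that the cyclopropyl of compound 1 is not needed for the lower number seen there. Hydrogen in place of cyclopropyl on the nitrogen gives a 1.0-fold higher number from compound 1 to compound 3 (0.01 log units; within the scatter) and leaves the two compounds within the scatter of each other, so among the three shown, it is the methoxy compound that stands apart from the two carrying a nitrogen on this carbon. Going by these compounds, compound 2 carries a limit of the assay and not a number, so how far it stands apart remains unknown: the limit of > 100000 nM in this assay, at which 1 of the 3 values shown sits.

Whether the oxygen or the methyl on it sets compound 2 apart stays open, as neither a hydroxyl nor an ethoxy group on this carbon is among the compounds shown. On these data alone, it is also open whether a dimethylamino or benzylamino group here would match amino and cyclopropylamino, and three compounds support no wider rule.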